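Removing the allyl group from compound 2

The source may hold more compounds than are shown below. What is called first, only, known or untested is meant among the compounds shown, and "the series" means these compounds.

In a functional assay on A549 cells (Homo sapiens) for cytotoxicity, read by resazurin assay, with a stated time of 72 h (a higher number here means a weaker inhibitor, a lower number a stronger inhibitor), compound 1 `COc1cc(OC)c(C(=O)/C=C/c2ccccc2)c(OC)c1` gives 4300 nM, and compound 2 `C=CCOc1ccccc1Cc1c(OC)cc(OC)c(C(=O)/C=C/c2ccccc2)c1OC` gives 8500 nM. These two numbers lie within the scatter of each other, so compound 2 stands level with compound 1 and no order can be read between them.

Compound 3 `COc1cc(OC)c(C(=O)/C=C/c2ccccc2)c(OC)c1Cc1ccccc1O` differs from compound 2 in one place: hydrogen in place of allyl on an oxygen on an aromatic ring. Hydrogen stands in place of allyl on an oxygen on an aromatic ring, which turns 2-(allyloxy)benzyl into 2-hydroxybenzyl.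

For the measured compounds named here, no measured pair covers this exact change, and no compound with the hydroxy group has a value yet. The nearest evidence is a 2.0-fold higher number from compound 1 to compound 2 (0.30 log units; within the scatter), a step that installs the whole 2-(allyloxy)benzyl group on an aromatic carbon and stays within the scatter. Removing only the allyl part of that group is therefore expected to give no step beyond the scatter. The estimated step is a 1.4-fold lower number from compound 2 to compound 3 (0.15 log units; within the scatter). Compound 3 is expected to give about 6000 nM in this assay, with an estimated range of 2500 nM to 15000 nM.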

Compound 3, half-maximal inhibitory concentration: 9300 nM
For compound 3 the middle estimate is 1.6-fold (0.19 log units) below the measured one; the measured number falls inside the stated range.
By their numbers in this assay, from the lowest: compounds 1, 2 and 3 (each within the scatter of the next, the first and the last beyond it).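

In this assay, hydrogen in place of allyl on the oxygen leaves the number without any readable change, with a 1.1-fold higher number from compound 2 to compound 3 (0.04 log units; within the scatter), so this assay does not separate 2-(allyloxy)benzyl from 2-hydroxybenzyl at this position. Set against the unsubstituted core, however, the 2-hydroxybenzyl group gives the first step in this series to pass the scatter, with a 2.2-fold higher number from compound 1 to compound 3 (0.34 log units; beyond the scatter), a modest move towards a weaker inhibitor, whereas the step with 2-(allyloxy)benzyl, a 2.0-fold higher number from compound 1 to compound 2 (0.30 log units; within the scatter), stays within it; since compound 2 and compound 3 remain level with each other, this small difference in reach gives no order between the two groups. Nothing available here offers an explanation for these numbers.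

Going by these compounds, it remains open whether a longer chain than allyl on this oxygen, or an amine or a carboxylic acid in place of the hydroxy group, would move the number beyond the scatter from compound 3. On these data alone, it is also open whether a benzyl group with no substituent on its ring would stand level with compound 3 in this assay or differ from it.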